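Alpha-ketooxazole series: substituent at the oxazole carbon

A few compounds are considered here, and "the series" means these few. Any claim that something is new, unique, unknown or untested is made for them only; others in the source may bear on it.

Measured so far:
compound 1, `O=C(CCc1ccc(COc2ccccc2)cc1)c1ncco1`: 25 nM
compound 2, `O=C(CCc1ccc(COc2ccccc2)cc1)c1ncc(I)o1`: 4 nM

Among the compounds with values here, in an assay for inhibition of Fatty-acid amide hydrolase 1 (Rattus norvegicus) (on this read-out higher numbers stand for weaker inhibition and lower numbers for stronger inhibition), compound 2 stands at the lowest of the two numbers so far; the nearest is compound 1 with a higher number, and the gap is a 6.3-fold lower number from compound 1 to compound 2 (0.80 log units; beyond the scatter). Compound 3, `COC(=O)c1cnc(C(=O)CCc2ccc(COc3ccccc3)cc2)o1`, is not yet measured. Its difference from compound 2 is methoxycarbonyl in place of iodo on an aromatic carbon. Within the data shown here, only one measured step bears on this site: the move from hydrogen to iodo on the same aromatic carbon, a 6.3-fold lower number from compound 1 to compound 2 (0.80 log units; beyond the scatter), shows that a group at this position is tolerated and gave a lower number. Among the measured compounds shown here, no step tells how methoxycarbonyl compares with iodo there, so the expected step of a 1.3-fold higher number from compound 2 to compound 3 (0.10 log units; within the scatter) is taken as none beyond the scatter, with the range widened toward compound 1. Compound 3 is therefore estimated at 5 nM, between 1.2 nM and 20 nM.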

Compound 3, inhibition constant: 1.6 nM
Beside the measured number, compound 3's estimate is 3.1-fold (0.49 log units) above it, within the range that was stated.
By their numbers in this assay, from the lowest: compound 3; then compound 2; then compound 1.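

Methoxycarbonyl and iodo can be told apart at this carbon next to the ring oxygen: in this assay the exchange gives a 2.5-fold lower number from compound 2 to compound 3 (0.40 log units; beyond the scatter), so the lower number seen earlier is not confined to iodo. Measured against hydrogen, methoxycarbonyl gives a 16-fold lower number from compound 1 to compound 3 (1.19 log units; beyond the scatter), the largest step at this site so far, with a group that brings hydrogen-bond acceptors where iodo has none. Nothing on hand explains this order among hydrogen, iodo and methoxycarbonyl.

Going by these compounds, whether the trend belongs to the methyl ester or extends to other carbonyl-bearing groups stays open; a carboxylic acid, a primary amide or an ethyl ester at the same carbon would test this. A nitrile or an amine there could also show whether hydrogen-bond acceptors track with the numbers.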